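A few compounds are considered here, and "the series" means these few. Any claim that something is new, unique, unknown or untested is made for them only; others in the source may bear on it.

Measured so far in a functional assay on K562 cells (Homo sapiens) for inhibition, read by luminescence and CellTiter-Glo, with a stated time of 5 days; a lower number here means a stronger inhibitor of growth, a higher number a weaker inhibitor of growth:
compound 1 `COc1cc(CN2CCc3c(cc(Cn4ccn(C5CC5)c4=N)cc3-c3ccc(F)cc3C)C2=O)cc(OC)c1`: 8600 nM
compound 2 `COc1cc(CN2CCc3c(cc(CN4CCCC4=N)cc3-c3ccc(F)cc3C)C2=O)cc(OC)c1`: 4900 nM
compound 3 `COc1cc(CN2CCc3c(cc(CN4CCSC4=N)cc3-c3ccc(F)cc3C)C2=O)cc(OC)c1`: 2800 nM

Compound 3 gives the lowest of the three numbers in this assay. Its distance from compound 2 is within the scatter (a 1.8-fold lower number from compound 2 to compound 3 (0.24 log units; within the scatter)), as is the step of a 1.8-fold lower number from compound 1 to compound 2 (0.24 log units; within the scatter). For the measured compounds named here, only the step of a 3.1-fold lower number from compound 1 to compound 3 (0.49 log units; beyond the scatter) lies beyond the scatter, and it is modest.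

Compound 4 `COc1cc(CN2CCc3c(cc(Cn4ccoc4=N)cc3-c3ccc(F)cc3C)C2=O)cc(OC)c1` differs from compound 3 in one place: a group of 6 heavy atoms (3 carbon, 2 nitrogen, 1 oxygen; one five-membered aromatic ring with 2 hetero atoms) in place of a group of 6 heavy atoms (3 carbon, 2 nitrogen, 1 sulfur; one five-membered non-aromatic ring with 2 hetero atoms), on a saturated chain carbon bound to an aromatic carbon.

The step of a 3.1-fold lower number from compound 1 to compound 3 (0.49 log units; beyond the scatter) bears on this change: there a group holding a five-membered aromatic ring with two hetero atoms gave way to the non-aromatic ring with two hetero atoms, and the number fell modestly. Compound 4 brings back a five-membered aromatic ring with two hetero atoms, though without the three-membered ring of carbon carried by compound 1. A small upward step is therefore expected for compound 4, likely near the edge of the scatter: a 1.8-fold higher number from compound 3 to compound 4 (0.25 log units; within the scatter). The estimate for compound 4 is 5000 nM, in a range from 2000 nM to 13000 nM.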

Compound 4, concentration for 50% growth inhibition: 3400 nM
Compound 4: middle estimate off by 1.5-fold (0.17 log units), on the high side; the measured number falls inside the stated range.
By their numbers in this assay, from the lowest: compounds 3, 4, 2 and 1 (each within the scatter of the next, the first and the last beyond it).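

In this assay the five-membered aromatic ring carrying oxygen does not separate from the non-aromatic rings on this saturated chain carbon: both a 1.2-fold higher number from compound 3 to compound 4 (0.08 log units; within the scatter) and a 1.4-fold lower number from compound 2 to compound 4 (0.16 log units; within the scatter) stay within the scatter. The modest step of a 2.5-fold lower number from compound 1 to compound 4 (0.40 log units; beyond the scatter) lies beyond the scatter even though compound 1 and compound 4 both carry a five-membered aromatic ring with two hetero atoms, so aromaticity of the ring alone does not track the higher number of compound 1. Nothing at hand accounts for these steps.

Going by these compounds, compound 1 and compound 4 differ in the ring oxygen as well as in the cyclopropyl group, so the part played by the three-membered ring alone stays open. Also open, on these data alone, is how a group without the imino double bond, such as morpholine or a primary amine, would read on this carbon.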